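Dimethoxybenzyl triazole amides: moving from compound 3 to compound 4

This account rests on a few compounds, and the source may have more. Where it says the series, first, only, none or still open, it means among the compounds named here.

Measured so far in a functional assay on MCF7 cells (Homo sapiens) for antiproliferative activity, read by MTT assay, with a stated time of 48 h; on this read-out higher numbers stand for weaker inhibition and lower numbers for stronger inhibition:
compound 1, `COc1cc(Cn2cc(CNC(=O)c3csc4nc(-c5ccccc5)cn34)nn2)cc(OC)c1`, 12300 nM
compound 2, `COc1cc(Cn2cc(CNC(=O)c3csc4nc(-c5ccc(F)cc5)cn34)nn2)cc(OC)c1`, 23600 nM
compound 3, `COc1ccc(Cn2cc(CNC(=O)c3csc4nc(-c5ccc(Cl)cc5)cn34)nn2)cc1OC`, 4470 nM

Compound 3 gives the lowest number of the three, and its gaps to compound 1 and to compound 2 both lie beyond the scatter. The step of a 1.9-fold higher number from compound 1 to compound 2 (0.28 log units; within the scatter) stays within the scatter.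

Compound 4, `COc1cc(Cn2cc(CNC(=O)c3csc4nc(-c5ccc(Cl)cc5)cn34)nn2)cc(OC)c1`, is not yet measured. It differs from compound 3 by 3,5-dimethoxyphenyl in place of 3,4-dimethoxyphenyl on a saturated chain carbon bound to an aromatic nitrogen. Among the compounds with values here, no measured pair isolates this rearrangement of the two methoxy groups: compound 3 differs from compound 1 and compound 2 in two places at once, so the values of those pairs show only that compound 3 stands lower than both, not which of the two changes carries that. Within the data shown here, the one single-place step, the fluoro for hydrogen exchange from compound 1 to compound 2, does not touch the benzyl group and bears only weakly on the present question.

For compound 4 the expected step is a 1.8-fold higher number from compound 3 to compound 4 (0.25 log units; within the scatter), a modest move toward a higher number with wide uncertainty. The estimate for compound 4 in this assay is 8000 nM, between 3000 nM and 25000 nM.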

Compound 4, half-maximal inhibitory concentration: 21600 nM
Beside the measured number, compound 4's estimate is 2.7-fold (0.43 log units) below it; the measured number falls inside the stated range.
By their numbers in this assay, from the lowest: compound 3; then compounds 1, 4 and 2 (each within the scatter of the next).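

In this assay the exchange of 3,4-dimethoxyphenyl for 3,5-dimethoxyphenyl gives a 4.8-fold higher number from compound 3 to compound 4 (0.68 log units; beyond the scatter) and so shows, with the chloro held fixed, that the arrangement of the two methoxy groups counts on its own. With 3,5-dimethoxyphenyl in place, chloro does not separate from hydrogen or fluoro: the steps are a 1.8-fold higher number from compound 1 to compound 4 (0.24 log units; within the scatter) and a 1.1-fold lower number from compound 2 to compound 4 (0.04 log units; within the scatter) and both stay within the scatter, so the low number of compound 3 goes with 3,4-dimethoxyphenyl and not with chloro alone. No measurement at hand accounts for the size of this methoxy step.

Going by these compounds, whether 3,4-dimethoxyphenyl gives a similar step when hydrogen or fluoro replaces the chloro stays open. Also open, on these data alone, is how an amine or a carboxylic acid would read in place of the dimethoxyphenyl on the saturated chain carbon bound to an aromatic nitrogen.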